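The source may hold more compounds than are shown below. What is called first, only, known or untested is meant among the compounds shown, and "the series" means these compounds.

Series notes. Compound 1 `NC(=O)/C(=N/O)Nc1ccc(F)c(Cl)c1` sits at the weak end of the set: in an assay on SK-OV-3 cells for inhibition of Indoleamine 2,3-dioxygenase 1 (Homo sapiens) (on this read-out higher numbers stand for weaker inhibition and lower numbers for stronger inhibition), compound 1 gives 24000 nM. Compound 2 `O=C(Nc1ccc(Cl)cc1)C(=O)N1CCC(c2ccnc3ccc(F)cc23)CC1` is the hydroxy-free member of the shared core; in this assay compound 2 gives 15 nM. Compound 3 `O=C(Nc1ccc(Cl)cc1)C(=O)N1CC[C@H](c2ccnc3ccc(F)cc23)[C@@H](O)C1` carries a hydroxy on a saturated ring carbon; in this assay compound 3 gives 6.1 nM. Among the measured compounds shown here, the one measured step within the set is a 2.5-fold lower number from compound 2 to compound 3 (0.39 log units; beyond the scatter). Compound 3 therefore stands lowest of the three numbers, with compound 2 nearest and compound 1 furthest, both gaps beyond the scatter.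

Compound 4 `O=C(Nc1ccc(Cl)cc1)C(=O)N1CC[C@@H](c2ccnc3ccc(F)cc23)[C@H](O)C1` is the next point. Against compound 3 the change is the two compounds have the same atoms and bonds and differ only in configuration as drawn: 2 of 2 stereo elements differ (all stereocentres are inverted: mirror images); a stereocentre at a saturated ring carbon is drawn R in compound 3 and S in compound 4; a stereocentre at a saturated ring carbon is drawn R in compound 3 and S in compound 4. For the measured compounds named here, no measured step involves an inversion of configuration: the step from compound 2 to compound 3 concerns a hydroxy entering and says nothing about a mirror image, so it does not bear on this move. The set holds no other pair of mirror images either, so the size of the step cannot be read from the numbers shown, and the expectation is set wide. For compound 4 the expected step is a 4.1-fold higher number from compound 3 to compound 4 (0.61 log units; beyond the scatter), toward a higher number. Compound 4 is estimated at 25 nM, between 4 nM and 150 nM.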

Compound 4, half-maximal inhibitory concentration: 50 nM
For compound 4 the middle estimate is 2.0-fold (0.30 log units) below the measured one; the measured number falls inside the stated range.
By their numbers in this assay, from the lowest: compound 3; then compound 2; then compound 4; then compound 1.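

Adding a hydroxy on a saturated ring carbon has no single direction in this series: with the configuration of compound 3 the result is a 2.5-fold lower number from compound 2 to compound 3 (0.39 log units; beyond the scatter), whereas with the mirror-image configuration it is a 3.3-fold higher number from compound 2 to compound 4 (0.52 log units; beyond the scatter). Inverting both stereocentres gives an 8.2-fold higher number from compound 3 to compound 4 (0.91 log units; beyond the scatter), so in this assay the drawn configuration at these ring carbons decides whether the hydroxy compound falls below or above the hydroxy-free compound 2. With no atom or bond changed, this separation can be assigned to configuration alone, because nothing else distinguishes the pair: the fact that compounds 3 and 4 differ only in the configuration as drawn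

From the compounds shown here alone, both stereocentres invert together in this pair, so the share of each centre in the step remains open, as does the outcome for a form with only one of them inverted. Also open, going by these compounds, is whether a methoxy group or an amine in place of the hydroxy would divide the two configurations in the same direction, or whether this split is particular to the hydroxy.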